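Swapping Fluoro for Trifluoromethyl on a Shared Core

The compounds below may be only part of what the source reports. "The series", "measured", "known", "first", "only" and "open" are said of these compounds alone.

Measured in an assay on mitochondria from L6 cells (Rattus norvegicus) for activation, with a stated time of 90 min; on this read-out lower numbers stand for an effect already at smaller amounts and higher numbers for an effect only at larger amounts of compound:
compound 1 `Oc1nc2nonc2nc1Nc1ccccc1F`: 12500 nM
compound 2 `Oc1nc2nonc2nc1Nc1cccc(C(F)(F)F)c1`: 13300 nM
compound 3 `Oc1nc2nonc2nc1Nc1cccc(F)c1F`: 9700 nM

All three share one core and differ only in the groups on the aromatic ring attached through the amine. Compound 3 gives the lowest of the three numbers, but only by steps within the scatter: a 1.3-fold lower number from compound 1 to compound 3 (0.11 log units; within the scatter), and its gap to compound 2 is of the same kind, so none of the three can be told apart. Compound 4 `Oc1nc2nonc2nc1Nc1cccc(C(F)(F)F)c1F` arises from compound 3 by trifluoromethyl in place of fluoro on an aromatic carbon. Among the measured compounds shown here, the single measured step, a 1.3-fold lower number from compound 1 to compound 3 (0.11 log units; within the scatter), concerned a different change and stayed within the scatter; the values of compound 1 and compound 2 likewise show that a trifluoromethyl and a fluoro on this ring gave near-identical numbers. In this assay compound 4 is therefore expected to show a 1.0-fold higher number from compound 3 to compound 4 (0.01 log units; within the scatter), nothing beyond the scatter. The estimate for compound 4 is 10000 nM, ranging from 4000 nM to 25000 nM.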

Compound 4, half-maximal effective concentration: 4900 nM
Compound 4: middle estimate off by 2.0-fold (0.31 log units), on the high side; the range from low to high includes it.
By their numbers in this assay, from the lowest: compounds 4, 3, 1 and 2 (each within the scatter of the next, the first and the last beyond it).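

In this assay, trifluoromethyl in place of fluoro at this position gives a 2.0-fold lower number from compound 3 to compound 4 (0.30 log units; within the scatter), so the larger group fits here without a step past the scatter. Trifluoromethyl in place of hydrogen gives a 2.6-fold lower number from compound 1 to compound 4 (0.41 log units; beyond the scatter), and fluoro in place of hydrogen gives a 2.7-fold lower number from compound 2 to compound 4 (0.43 log units; beyond the scatter), the first steps beyond the scatter. The fluoro change does not clearly differ with or without trifluoromethyl on the ring: the same change on two cores in this assay, a 1.3-fold lower number (0.11 log units; within the scatter) from compound 1 to compound 3 and a 2.7-fold lower number (0.43 log units; beyond the scatter) from compound 2 to compound 4, 2.1-fold (0.32 log units) apart, within the scatter of two such steps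

On these data alone, whether another group at this position, such as an amine, a carboxylic acid or a longer chain, would keep or shift the number remains open.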